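Truncation of the amide ether side chain

This account rests on a few compounds, and the source may have more. Where it says the series, first, only, none or still open, it means among the compounds named here.

Measured so far:
Compound 1 `O=C(COc1ccc2cc(C(O)(C(F)(F)F)C(F)(F)F)c(O)cc2c1)Nc1ccccc1` — in an assay on isolated protein for inhibition of receptor-type tyrosine-protein phosphatase C (Homo sapiens), read by spectrophotometry (on this read-out lower numbers stand for stronger inhibition and higher numbers for weaker inhibition), compound 1 gives > 20000 nM, a limit of the assay.
Compound 2 `CCCNC(=O)COc1ccc2cc(C(O)(C(F)(F)F)C(F)(F)F)c(O)cc2c1` — in this assay compound 2 gives > 20000 nM, again a limit.
Compound 3 `O=C(COc1ccc2cc(C(O)(C(F)(F)F)C(F)(F)F)c(O)cc2c1)Nc1cccc2ccccc12` — in this assay compound 3 gives 29100 nM.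

Compound 2 thus stands at the upper limit of this assay (the limit of > 20000 nM in this assay, at which 2 of the 3 values shown sit). Compound 4 `Oc1cc2ccccc2cc1C(O)(C(F)(F)F)C(F)(F)F` differs from compound 2 by hydrogen in place of (propylcarbamoyl)methoxy on an aromatic carbon. The measured steps all concern the amide substituent and are unreadable: a step that the two limits leave unreadable from compound 1 to compound 2, a step that the limit leaves unreadable from compound 1 to compound 3 and a step that the limit leaves unreadable from compound 2 to compound 3. None of them tests removal of the whole chain, so no direction can be read from them. The expectation for compound 4 is therefore weak inhibition near the limit, estimated at 30000 nM with a range from 10000 nM to 100000 nM. The expected step that the limit leaves unreadable from compound 2 to compound 4 is taken as none beyond the scatter.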

Compound 4, half-maximal inhibitory concentration: 112000 nM
Compound 4: middle estimate off by 3.7-fold (0.57 log units), on the low side; measured number above the stated range.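

Compound 2 gives only a limit, so no new step can be read between it and compound 4: the limit of > 20000 nM in this assay, at which 2 of the 4 values shown sit.

The compounds shown leave open the direction and size of any change in inhibition when hydrogen replaces (propylcarbamoyl)methoxy on the shared core.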